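A Shorter Amine Tail on the Shared Core

This account rests on a few compounds, and the source may have more. Where it says the series, first, only, none or still open, it means among the compounds named here.

Measured so far:
compound 1 `CC(C)c1n[nH]c2c(NCc3ccc(-c4ccccn4)cc3)nc(SCC(O)C(F)(F)F)nc12` gives 690 nM in a functional assay on HT cells (Homo sapiens) for antiproliferative activity, read by fluorescence, with a stated time of 72 h; a higher number here means a weaker inhibitor of growth, a lower number a stronger inhibitor of growth
compound 2 `CNCCSc1nc(NCc2ccc(-c3ccccn3)cc2)c2[nH]nc(C(C)C)c2n1` gives 56 nM in this assay
compound 3 `CC(C)c1n[nH]c2c(NCc3ccc(-c4ccccn4)cc3)nc(SCC(O)CN3CCNCC3)nc12` gives 332 nM in this assay

Compound 3 stands second highest of the three numbers in this assay: compound 1 sits above it by a 2.1-fold lower number from compound 1 to compound 3 (0.32 log units; beyond the scatter) read the other way, while compound 2 lies well below it, since a 5.9-fold higher number from compound 2 to compound 3 (0.77 log units; beyond the scatter).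

The next compound, compound 4 `CC(C)c1n[nH]c2c(NCc3ccc(-c4ccccn4)cc3)nc(SCCN)nc12`, keeps the shared core and the sulfur-bound chain but trims the tail:

aminomethyl in place of 1-hydroxy-2-(piperazin-1-yl)ethyl on a saturated chain carbon bound to a sulfur

Within the data shown here, two measured steps bear on this. The first, a 12-fold lower number from compound 1 to compound 2 (1.09 log units; beyond the scatter), shows that a small amine-bearing chain on the sulfur is far better in this assay than the trifluoro-hydroxy chain. The second, a 5.9-fold higher number from compound 2 to compound 3 (0.77 log units; beyond the scatter), shows that replacing that small amine chain with the longer hydroxy-piperazine chain costs a clear amount. Compound 4 carries aminomethyl, which differs from the (methylamino)methyl of compound 2 only by one methyl group, so the step from compound 3 to compound 4 is expected to reverse most of the loss seen in compound 3 and to be a clear downward one, about a 4.4-fold lower number from compound 3 to compound 4 (0.65 log units; beyond the scatter).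

Compound 4 is therefore expected to land near 75 nM in this assay, with a likely range from 30 nM to 200 nM.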

Compound 4, concentration for 50% growth inhibition: 22 nM
The estimate for compound 4 lay 3.4-fold (0.53 log units) above the measured number; the whole stated range lies above it.
By their numbers in this assay, from the lowest: compound 4; then compound 2; then compound 3; then compound 1.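

In this assay the plain 2-aminoethyl chain on the sulfur gives the lowest number of the four compounds, with a 15-fold lower number from compound 3 to compound 4 (1.18 log units; beyond the scatter) and a 31-fold lower number from compound 1 to compound 4 (1.50 log units; beyond the scatter) marking large gains over both chains that carry a hydroxy group. Among these compounds, what the earlier compounds could not show is that a single methyl on the amine nitrogen already changes the result, since removing it gives a 2.5-fold lower number from compound 2 to compound 4 (0.41 log units; beyond the scatter) as a modest step that still lies beyond the scatter, so at this position the unsubstituted amine outperforms the methylated one. Nothing measured here explains why the chains fall in this order.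

The compounds shown leave open whether the nitrogen of the tail is needed at all, which a 2-hydroxyethyl chain on the sulfur would test, and whether a longer chain such as 3-aminopropyl would keep the gain. They also leave open how much of the higher number of compound 3 belongs to the hydroxy group and how much to the piperazine, as the two arrive together in that compound and nothing shown separates them.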